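Swapping a benzyl ester for a diethyl amide

This account rests on a few compounds, and the source may have more. Where it says the series, first, only, none or still open, it means among the compounds named here.

compound 1 `COc1ccc(-c2cc3c(OC)cc(OC)cc3n(CC(=O)OCc3ccccc3)c2=O)cc1` gives 10000 nM
compound 2 `COc1ccc(-c2cc3c(OC)cc(OC)cc3n(CCC(=O)OCc3ccccc3)c2=O)cc1` gives 10000 nM

For the measured compounds named here, in a functional assay on LoVo cells (Homo sapiens) for cytotoxicity, read by colorimetric assay and MTT assay (on this read-out lower numbers stand for stronger inhibition and higher numbers for weaker inhibition), compound 2 reads 10000 nM and stands level with compound 1, the only other compound measured so far. Compound 3 `CCN(CC)C(=O)CCn1c(=O)c(-c2ccc(OC)cc2)cc2c(OC)cc(OC)cc21` keeps the shared core and changes one group: diethylamino in place of benzyloxy on a carbonyl carbon. Put simply, this is diethylamino in place of benzyloxy on a carbonyl carbon, which turns benzyloxycarbonyl into diethylcarbamoyl.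

Going by the values given here, only one measured step is available as a guide: no change at the digits printed from compound 1 to compound 2 (within the scatter). That step leaves the benzyloxy group in place, so it bears on the new change only indirectly. Among the compounds with values here, it shows a flat reading between two benzyl esters, and no measured compound carries diethylamino. The data therefore give no reason to favour a gain or a loss, and the range has to stay wide.

The step expected in this assay is a 1.3-fold lower number from compound 2 to compound 3 (0.10 log units; within the scatter), which is an expectation of no change beyond the scatter. The estimated value for compound 3 is 8000 nM, with an expected range from 2500 nM to 15000 nM as its bounds.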

Compound 3, half-maximal inhibitory concentration: 10000 nM
Compound 3: the middle estimate sits 1.3-fold (0.10 log units) below what was measured; the measured number falls inside the stated range.
By their numbers in this assay, from the lowest: compounds 1, 2 and 3 (each within the scatter of the next).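

In this assay, replacing benzyloxy with diethylamino on a carbonyl carbon gives no change at the digits printed from compound 2 to compound 3 (within the scatter), so this position now has a reading for an amide as well as for benzyl esters, and losing the six-membered aromatic ring of the benzyloxy group leaves the printed number unmoved. The comparison that also takes in the shorter chain, (diethylcarbamoyl)methyl in place of benzyloxycarbonyl on a saturated chain carbon bound to an aromatic nitrogen, gives no change at the digits printed from compound 1 to compound 3 (within the scatter), which means that neither the ester group nor the benzyl ring is needed to hold this reading among the compounds shown. No measurement here explains why the reading stays flat across these changes.

On these data alone, it remains open whether a free carboxylic acid or a morpholine amide on the same carbonyl carbon would move the number away from this shared reading. A longer chain carrying the diethylcarbamoyl group, or a change to the methoxy groups on the shared core, is equally untested by the compounds shown here.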